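Methyl added to the sulfonyl aryl of compound 2

This account rests on a few compounds, and the source may have more. Where it says the series, first, only, none or still open, it means among the compounds named here.

Compound 2 `CC1CCN(c2c(S(=O)(=O)c3cccc(Cl)c3)cnc3cc(Cl)ccc23)CC1` gives 92% in an assay on isolated protein for displacement of a labelled ligand from metabotropic glutamate receptor 5 (Homo sapiens), with a stated time of 60 min, tested at 1 uM (on this read-out lower numbers stand for less inhibition and higher numbers for more inhibition at the one concentration tested (going by the name of the read-out)), level with compound 3 `CC1CCN(c2c(S(=O)(=O)c3ccc(Cl)cc3)cnc3ccc(Cl)cc23)CC1` at 92% and together the highest of the three numbers; compound 1 `Cc1ccc(S(=O)(=O)c2cnc3ccc(Cl)cc3c2N2CCC(C)CC2)cc1F` sits lowest at 68%. Compound 4 `Cc1ccc(S(=O)(=O)c2cnc3cc(Cl)ccc3c2N2CCC(C)CC2)cc1Cl` differs from compound 2 by methyl in place of hydrogen on an aromatic carbon. Among the measured compounds shown here, the only measured step on the sulfonyl aryl is a number 24 percentage points higher from compound 1 to compound 3 (beyond the scatter), which swaps a 3-fluoro-4-methylphenyl for a 4-chlorophenyl and so is not the same change; no step adds a methyl alone. For the measured compounds named here, compound 1, the one methyl-bearing analogue, gives 68%, so a modest loss is expected, though a number within the scatter of compound 2 cannot be excluded. Compound 4 is expected at 80%, range 55% to 96%, a step of a number 12 percentage points lower from compound 2 to compound 4 (beyond the scatter).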

Compound 4, a percentage reported as inhibition, at one concentration (the size of the read-out at that concentration, not a potency): 89%
Compound 4: middle estimate off by 9 percentage points, on the low side; the range from low to high includes it.
By their numbers in this assay, from the lowest: compound 1; then compounds 4, 2 and 3 (each within the scatter of the next).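

In this assay, the change from 3-chlorophenyl to 3-chloro-4-methylphenyl gives a number 3 percentage points lower from compound 2 to compound 4 (within the scatter), so with this methyl, ortho to a chloro group and para to a large group, the number stays level at the one concentration tested. Among the compounds shown here, this is the first step that changes only a methyl on the sulfonyl aryl. No supporting data bear on why the number stays level with the methyl in place.

Any potency gap between compound 2 and compound 4 stays open, as a single-concentration read-out cannot give one. Also open, as far as these compounds go, is what number a methoxy, an amine or a carboxylic acid would give on the same carbon.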